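From 2-chlorophenyl to 3-nitrophenyl on the shared core

The source may report more compounds than this note shows. Statements on the series, on what has been measured and on what is new or still open speak of the compounds shown alone.

In a functional assay on HepG2 cells (Homo sapiens) for inhibition, read by MTT assay, with a stated time of 72 h (a lower number here means a stronger inhibitor, a higher number a weaker inhibitor), compound 3 (`Cc1cc2occ(-c3nc(-c4ccccc4)c(-c4ccccc4)n3-c3ccccc3Cl)c(=O)c2cc1Cl`) gives 6250 nM, the second highest of three values. Compound 2 (`Cc1cc2occ(-c3nc(-c4ccccc4)c(-c4ccccc4)n3-c3ccc(Cl)cc3)c(=O)c2cc1Cl`) gives 1560 nM, and compound 1 (`Cc1cc2occ(-c3nc(-c4ccccc4)c(-c4ccccc4)n3-c3ccc([N+](=O)[O-])cc3)c(=O)c2cc1Cl`) gives 25000 nM. Compound 4 (`Cc1cc2occ(-c3nc(-c4ccccc4)c(-c4ccccc4)n3-c3cccc([N+](=O)[O-])c3)c(=O)c2cc1Cl`) carries 3-nitrophenyl in place of 2-chlorophenyl on an aromatic nitrogen. Going by the values given here, two measured steps bear most directly on this swap. Exchanging 4-nitrophenyl for 2-chlorophenyl gave a 4.0-fold lower number from compound 1 to compound 3 (0.60 log units; beyond the scatter), a modest step, while chloro in place of nitro gave a 16-fold lower number from compound 1 to compound 2 (1.20 log units; beyond the scatter), a large one. Moving the chlorine gave a 4.0-fold higher number from compound 2 to compound 3 (0.60 log units; beyond the scatter), also modest. No 3-substituted phenyl has been measured. A modest rise is therefore expected, namely a 2.0-fold higher number from compound 3 to compound 4 (0.30 log units; within the scatter). Compound 4 is estimated at 12500 nM, with an expected range of 4000 nM to 35000 nM.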

Compound 4, half-maximal inhibitory concentration: 25000 nM
Estimate against measurement, compound 4: 2.0-fold (0.30 log units) below, within the range that was stated.
By their numbers in this assay, from the lowest: compound 2; then compound 3; then compounds 1 and 4 (each within the scatter of the next).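

Between the two nitrophenyl groups on the aromatic nitrogen, the step shows no change at the digits printed from compound 1 to compound 4 (within the scatter) and so separates 3-nitrophenyl from 4-nitrophenyl by nothing that can be read. Both chlorophenyl compounds have lower numbers, with a 4.0-fold higher number from compound 3 to compound 4 (0.60 log units; beyond the scatter) and a 16-fold higher number from compound 2 to compound 4 (1.20 log units; beyond the scatter) as 3-nitrophenyl replaces 2-chlorophenyl and 4-chlorophenyl. Nothing available here accounts for these differences.

As far as these compounds go, it remains open whether a 3-chlorophenyl group would match the nitrophenyl compounds or the chlorophenyl compounds. Also open, from the compounds shown here alone, is what an aminophenyl or carboxyphenyl group would give at this position.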